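The compounds below may be only part of what the source reports. "The series", "measured", "known", "first", "only" and "open" are said of these compounds alone.

Measured compounds and their values:
Compound 1 `CCc1cc(-c2noc(-c3cc(C)nc(CN(C)CC(C)C)c3)n2)cc(C)c1OC[C@@H](O)CNC(=O)CO` — 1090 mL.min-1.g-1
Compound 2 `CCc1cc(-c2noc(-c3cc(C)cc(CN(C)C)c3)n2)cc(C)c1OC[C@@H](O)CNC(=O)CO` — > 4800 mL.min-1.g-1
Compound 3 `CCc1cc(-c2noc(-c3cc(C)cc(CN(C)CC(C)C)c3)n2)cc(C)c1OC[C@@H](O)CNC(=O)CO` — 740 mL.min-1.g-1

In an ADME assay on liver (strain Wistar) for metabolic stability, with Liver microsome (Rattus norvegicus) as the target, read by LC-MS, using microsomes and NADPH, with a stated time of 15 min, tested at 1 uM (on this read-out lower numbers stand for slow clearance and higher numbers for fast clearance), compound 2 gives > 4800 mL.min-1.g-1, which is a limit of the assay and not a number; compound 2 thus stands at the fast-clearance end of the three measured compounds, where (the limit of > 4800 mL.min-1.g-1 in this assay, at which 1 of the 3 values shown sits). Going by the values given here, compound 3 reaches 740 mL.min-1.g-1 and compound 1 reaches 1090 mL.min-1.g-1; the step of an at least 6.4-fold lower number from compound 2 to compound 3 (0.81 log units; beyond the scatter) is the only change that was measured directly, and it concerns the amine substituent, not the aryl ring.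

Compound 4 `CCc1cc(-c2nc(-c3cc(C)c(OC[C@@H](O)CNC(=O)CO)c(CC)c3)no2)ccc1CN(C)C` is not yet measured. It differs from compound 2 in 4-((dimethylamino)methyl)-3-ethylphenyl in place of 3-((dimethylamino)methyl)-5-methylphenyl on an aromatic carbon. Among the compounds with values here, no measured step touches the pattern of substituents on this aryl ring, so the measured data give no direct guide to the size or direction of this change. Within the data shown here, what is known is only that compound 2 sits at the limit, and that the one measured way of moving away from that limit, from compound 2 to compound 3, is not taken here. The expectation is therefore that compound 4 stays close to compound 2, with a modest step of an at least 1.3-fold lower number from compound 2 to compound 4 (0.13 log units; that floor lies within the scatter) at most, and that it may again reach the limit. Compound 4 is estimated at 3500 mL.min-1.g-1, within 1200 mL.min-1.g-1 to 4800 mL.min-1.g-1.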

Compound 4, intrinsic clearance in microsomes: 9200 mL.min-1.g-1
Compound 4: middle estimate off by 2.6-fold (0.42 log units), on the low side, outside the stated range (above it).
By their numbers in this assay, from the lowest: compounds 3 and 1 (each within the scatter of the next); then compound 4.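

No step can be read from compound 2 to compound 4, because the entry for compound 2 is a limit of the assay and not a number: the limit of > 4800 mL.min-1.g-1 in this assay, at which 1 of the 4 values shown sits.

The compounds shown leave open whether 4-((dimethylamino)methyl)-3-ethylphenyl in place of 3-((dimethylamino)methyl)-5-methylphenyl raises or lowers the clearance, and by how much.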